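The source may hold more compounds than are shown below. What is called first, only, known or untested is meant among the compounds shown, and "the series" means these compounds.

Three compounds have numbers so far in a functional assay on A549 cells (Homo sapiens) for inhibition, read by MTT assay, with a stated time of 72 h; on this read-out lower numbers stand for stronger inhibition and higher numbers for weaker inhibition:

- compound 1 `C=C(Cl)C(=O)Nc1cc(Nc2nc3c(c(-c4cn(C)c5ccc(F)cc45)n2)CSCC3)c(OC)cc1N(C)CCN(C)C` gives 864 nM
- compound 2 `C/C=C\C(=O)Nc1cc(Nc2nc3c(c(-c4cn(C)c5ccc(F)cc45)n2)CSCC3)c(OC)cc1N(C)CCN(C)C` gives 5310 nM
- compound 3 `C=C(Cl)C(=O)Nc1cc(Nc2nc3c(c(-c4cn(C)c5ccccc45)n2)CSCC3)c(OC)cc1N(C)CCN(C)C` gives 716 nM

Compound 3, at 716 nM in this assay, sits level with compound 1 at the low end of these numbers, since a 1.2-fold lower number from compound 1 to compound 3 (0.08 log units; within the scatter) is a step that cannot separate them. Compound 2 stands clearly higher than both.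

Compound 4 `C/C=C\C(=O)Nc1cc(Nc2nc3c(c(-c4cn(C)c5ccccc45)n2)CSCC3)c(OC)cc1N(C)CCN(C)C` is compound 3 with a single change: prop-1-en-1-yl in place of 1-chloroethenyl on a carbonyl carbon. The same exchange has been measured once, and it gave a 6.1-fold higher number from compound 1 to compound 2 (0.79 log units; beyond the scatter), a modest rise. Among the compounds with values here, the only other measured step, a 1.2-fold lower number from compound 1 to compound 3 (0.08 log units; within the scatter), is hydrogen in place of fluoro on an aromatic carbon, and it stays within the scatter. Within the data shown here, compound 3 therefore offers no sign from the numbers that the exchange should behave differently without the fluoro, although no measured pair tests this directly. A rise of similar size is expected in this assay, and the expected step is a 6.1-fold higher number from compound 3 to compound 4 (0.79 log units; beyond the scatter), resting on this one precedent. For compound 4 the estimate is 4400 nM, with an expected range of 2000 nM to 9000 nM.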

Compound 4, half-maximal inhibitory concentration: 6860 nM
Estimate against measurement, compound 4: 1.6-fold (0.19 log units) below; measured number inside the range.
By their numbers in this assay, from the lowest: compounds 3 and 1 (each within the scatter of the next); then compounds 2 and 4 (each within the scatter of the next).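

In this assay, within the data shown here, the exchange of 1-chloroethenyl for prop-1-en-1-yl on a carbonyl carbon now has a second reading, a 9.6-fold higher number from compound 3 to compound 4 (0.98 log units; beyond the scatter), so the rise no longer rests on the fluoro core alone, and the two readings agree: the same change on two cores in this assay, a 6.1-fold higher number (0.79 log units; beyond the scatter) from compound 1 to compound 2 and a 9.6-fold higher number (0.98 log units; beyond the scatter) from compound 3 to compound 4, 1.6-fold (0.19 log units) apart, within the scatter of two such steps The replacement of fluoro by hydrogen on an aromatic carbon, earlier read only with 1-chloroethenyl in place, now also has a reading with prop-1-en-1-yl, a 1.3-fold higher number from compound 2 to compound 4 (0.11 log units; within the scatter), and again it separates nothing: the same change on two cores in this assay, a 1.2-fold lower number (0.08 log units; within the scatter) from compound 1 to compound 3 and a 1.3-fold higher number (0.11 log units; within the scatter) from compound 2 to compound 4, 1.6-fold (0.19 log units) apart, within the scatter of two such steps Across these four compounds, the exchange on the carbonyl carbon raises the number on both cores, the fluoro-to-hydrogen replacement stays within the scatter on both, and no compound goes against either pattern.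

The compounds shown leave open how a plain ethenyl group, or a longer chain carrying an amine, would read on the same carbonyl carbon, so the rise cannot yet be tied to the loss of the chlorine or to the added carbon. They also leave open whether a chloro or a methoxy group on that aromatic carbon would stay within the scatter as hydrogen and fluoro do.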